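Changing the amine on the dithiocarbamate of compound 2

A few compounds are considered here, and "the series" means these few. Any claim that something is new, unique, unknown or untested is made for them only; others in the source may bear on it.

Of the compounds shown here, three sharing one core have been measured in a functional assay on MGC-803 cells (Homo sapiens) for antiproliferative activity, read by CCK-8 assay, with a stated time of 72 h, tested at 2 uM; on this read-out higher numbers stand for a stronger effect at the one concentration tested and lower numbers for a weaker effect. Compound 1 `Nc1ccccc1NC(=O)c1ccc(CSC(=S)N2CCN(Cc3ccccn3)CC2)cc1` gives 23.4%. For the measured compounds named here, compound 3 `COc1ccc(N2CCN(C(=S)SCc3ccc(C(=O)Nc4ccccc4N)cc3)CC2)cc1` gives 25.3%, and the only single-point step among them, a number 1.9 percentage points higher from compound 1 to compound 3 (within the scatter), shows that swapping the substituent on the amine nitrogen in a ring left the read-out unchanged. Compound 2 `Nc1ccccc1NC(=O)c1ccc(CSC(=S)N2CCc3ccccc32)cc1` gives 44%, which places it highest of the three, beyond the scatter from both compound 3 and compound 1.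

The next compound, compound 4 `CCN(Cc1ccncc1)C(=S)SCc1ccc(C(=O)Nc2ccccc2N)cc1`, differs from compound 2 at the thiocarbonyl carbon: ethyl((pyridin-4-yl)methyl)amino in place of 2,3-dihydro-1H-indol-1-yl on a thiocarbonyl carbon. Going by the values given here, no measured step matches this change, since the step from compound 1 to compound 3 only alters what sits on an amine nitrogen in a ring, whereas here the ring amine itself gives way to an acyclic one. The two compounds with other amines at this position both sit far below compound 2, so a move back toward their level is expected rather than none. Compound 4 is therefore estimated at 30%, between 15% and 48%, which means an expected step of a number 14 percentage points lower from compound 2 to compound 4 (beyond the scatter).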

Compound 4, a percentage reported as inhibition, at one concentration (the size of the read-out at that concentration, not a potency): 71.6%
Compound 4: middle estimate off by 41.6 percentage points, on the low side, outside the stated range (above it).
By their numbers in this assay, from the lowest: compounds 1 and 3 (each within the scatter of the next); then compound 2; then compound 4.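

In this assay, the step of a number 27.6 percentage points higher from compound 2 to compound 4 (beyond the scatter) shows that replacing 2,3-dihydro-1H-indol-1-yl on the thiocarbonyl carbon can raise the read-out, whereas the other replacements shown, in compound 1 and compound 3, gave lower numbers than compound 2. The entering ethyl((pyridin-4-yl)methyl)amino has no five-membered non-aromatic ring and has a hydrogen-bond acceptor that the leaving group lacks, so this single step changes several features at once. No supporting measurement accounts for the rise.

The compounds shown leave open whether the ethyl group, the pyridin-4-yl ring or the open-chain amine accounts for the higher number. Nor do they show how the read-out would respond to a propyl chain in place of ethyl, or a benzyl group in place of (pyridin-4-yl)methyl.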